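The source may report more compounds than this note shows. Statements on the series, on what has been measured and on what is new or still open speak of the compounds shown alone.

Measured so far in a functional assay on MDA-MB-231 cells (Homo sapiens) for cytotoxicity, read by MTT assay, with a stated time of 72 h; on this read-out lower numbers stand for stronger inhibition and higher numbers for weaker inhibition:
- compound 1 `CCN(CC)Cc1ccc2nc(NC(=O)N/N=C/c3cn(Cc4ccc(C(C)(C)C)cc4)c4ccccc34)sc2c1` gives 2120 nM in this series
- compound 2 `CN(C)Cc1ccc2nc(NC(=O)N/N=C/c3cn(Cc4ccc(C(C)(C)C)cc4)c4ccccc34)sc2c1` gives 2230 nM in this series
- compound 3 `CN(C)Cc1ccc2nc(NC(=O)N/N=C3\C(=O)Nc4ccc(F)cc43)sc2c1` gives "not determined" (no result reported) and offers no number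

Among the compounds with values here, only two numbers exist, and compound 1 stands level with compound 2 (a 1.1-fold higher number from compound 1 to compound 2 (0.02 log units; within the scatter)).

Compound 4 `CCN(CC)Cc1ccc2nc(NC(=O)N/N=C/c3cn(Cc4ccc(Cl)cc4Cl)c4ccccc34)sc2c1` keeps the core and the diethylamino group of compound 1. The change is 2,4-dichlorophenyl in place of 4-(tert-butyl)phenyl on a saturated chain carbon bound to an aromatic nitrogen, which reads, one bond further out, as 4-(tert-butyl)benzyl to 2,4-dichlorobenzyl. Within the data shown here, the one measured step, dimethylamino in place of diethylamino, lies elsewhere, on a saturated chain carbon bound to an aromatic carbon, and bears only indirectly. Among the measured compounds shown here, compound 1 and compound 2 both carry 4-(tert-butyl)phenyl, so no measured step tests this change, and the data give no direction for it.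

In this assay no step beyond the scatter is expected, the estimate being a 1.2-fold lower number from compound 1 to compound 4 (0.07 log units; within the scatter) with low confidence. Compound 4 is estimated at 1800 nM, with an expected range of 600 nM to 5000 nM around that figure.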

Compound 4, half-maximal inhibitory concentration: 3280 nM
Compound 4: the middle estimate sits 1.8-fold (0.26 log units) below what was measured; measured number inside the range.
By their numbers in this assay, from the lowest: compounds 1, 2 and 4 (each within the scatter of the next).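

In this assay, within the data shown here, the first reading at the saturated chain carbon bound to an aromatic nitrogen is a 1.5-fold higher number from compound 1 to compound 4 (0.19 log units; within the scatter), so 4-(tert-butyl)benzyl and 2,4-dichlorobenzyl cannot be told apart here, although the two aryl groups share no substituent and 10 carbon heavy atoms give way to 8 heavy atoms that include 2 chlorine. The earlier step tested only the amine on the other side of the molecule, whereas this one shows that the aryl group can also be exchanged without a step beyond the scatter. No measured evidence bears on this result.

From the compounds shown here alone, whether an aryl group carrying a carboxylic acid or an amine would give a step beyond the scatter remains open. So does the effect of a longer chain in place of the benzyl carbon.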